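An estimate for compound 4 before it is measured

The source may hold more compounds than are shown below. What is called first, only, known or untested is meant among the compounds shown, and "the series" means these compounds.

Measured compounds, with their results in an ADME assay on Vero cells (Chlorocebus sabaeus) for cytotoxicity, read by MTT assay, with a stated time of 72 h; a higher number here means that more compound is tolerated, a lower number that less compound is tolerated:
compound 1, `COC(=O)c1cc(-c2cccc(NC(=O)c3ccc(C4OC4C(=O)c4ccc(Cl)cc4)cc3)c2)on1`, gives > 20 ug/mL, which is a limit of this assay.
compound 2, `COC(=O)c1cc(-c2cccc(NC(=O)c3ccc(/C=C/C(=O)c4cc(F)ccc4F)cc3)c2)on1`, gives > 40 ug/mL, which is a limit of this assay.
compound 3, `CC(C)Cc1ccc(C(=O)/C=C/c2ccc(C(=O)O)cc2)cc1`, gives < 10 ug/mL, which is a limit of this assay.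

Compound 2 therefore stands at the limit of > 40 ug/mL in this assay, at which 1 of the 3 values shown sits, and no number is known for it. Among the compounds with values here, the only step between measured compounds that share a single point of difference is a step that the two limits leave unreadable from compound 1 to compound 2, and since both ends are limits its size cannot be read.

Compound 4, `COC(=O)c1cc(-c2cccc(NC(=O)c3ccc(/C=C/C(=O)c4ccc(C)cc4)cc3)c2)on1`, differs from compound 2 by 4-methylphenyl in place of 2,5-difluorophenyl on a carbonyl carbon. Within the data shown here, no measured step covers this exchange, and compound 3, which lacks the amide of compound 2, stands at the limit of < 10 ug/mL in this assay, at which 1 of the 3 values shown sits, and gives no guidance on a change at the carbonyl-bound ring. All that the numbers offer is that compound 2 is tolerated at least up to its limit. On that basis, compound 4 is expected to behave much like compound 2, with an estimated step of a number no higher from compound 2 to compound 4 (the limit leaves the size open), most likely again reported only as a limit. The estimate for compound 4 in this assay is 40 ug/mL, within a range from 15 ug/mL to 80 ug/mL.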

Compound 4, half-maximal cytotoxic concentration: > 80 ug/mL
Compound 4 ended at the assay's limit; the forecaster's own chance of this, stated with the estimate: 65%; middle value at least 2.0-fold (0.30 log units) from the limit.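

In this assay compound 4 gives > 80 ug/mL, which is a limit and not a number. Compound 1 and compound 2 also stand at limits, and the steps from either of them to compound 4 cannot be read. The compounds shown leave open whether 4-methylphenyl in place of 2,5-difluorophenyl on a carbonyl carbon changes the tolerated concentration at all.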